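Methoxy on the seven-membered ring: what to expect for compound 3

A few compounds are considered here, and "the series" means these few. Any claim that something is new, unique, unknown or untested is made for them only; others in the source may bear on it.

compound 1 `CCOC(=O)C(=O)Nc1cccccc1=O` — 80%
compound 2 `CCOC(=O)C(=O)Nc1ccccc(OC)c1=O` — 24%

Going by the values given here, in a functional assay on the whole organism (strain Sprague-Dawley CD) for inhibition, with Rattus norvegicus as the target, read by paw edema, at a dose of 10 mg/kg by the intraperitoneal route (a lower number here means a weaker effect, a higher number a stronger effect of the compound at the dose given), compound 1 gives 80%, the highest of the two numbers so far; the nearest is compound 2, which gives 24%. Among the compounds with values here, the one measured step, a number 56 percentage points lower from compound 1 to compound 2 (beyond the scatter), is the only one that bears on the change at hand.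

Compound 3 `CCOC(=O)C(=O)Nc1cccc(OC)cc1=O` is not yet measured. It differs from compound 1 by methoxy in place of hydrogen on an aromatic carbon. Compound 2 carries the same group on the same ring at another carbon, and that step was large and downward. Within the data shown here, a downward step of comparable size is therefore expected for compound 3, though only one placement of the group has been measured and the range is set wide. Compound 3 is expected to give 35%, between 10% and 65%. The expected step is a number 45 percentage points lower from compound 1 to compound 3 (beyond the scatter).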

Compound 3, a percentage reported as inhibition, in the whole organism at one dose (the size of the read-out at that dose, not a potency): 73%
Compound 3: middle estimate off by 38 percentage points, on the low side; measured number above the stated range.
By their numbers in this assay, from the lowest: compound 2; then compounds 3 and 1 (each within the scatter of the next).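

In this assay the replacement of hydrogen by methoxy, on the aromatic carbon three ring bonds from the ring atom that bears a group of 8 heavy atoms, reads as a number 7 percentage points lower from compound 1 to compound 3 (within the scatter) and so costs no measurable effect at this position. The same replacement at the other ring carbon reads as a number 56 percentage points lower from compound 1 to compound 2 (beyond the scatter) and so the loss seen there does not follow from methoxy on the ring as such, but goes with the carbon that carries it, with compound 3 as the case that shows this. No measurement on hand accounts for the difference between the two placements.

The compounds shown leave open how methoxy behaves on the remaining ring carbons. Also open, on these data alone, is whether this position accepts other groups, such as an amine, a hydroxyl or a longer ethoxy chain, as it accepts methoxy.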